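A few compounds are considered here, and "the series" means these few. Any claim that something is new, unique, unknown or untested is made for them only; others in the source may bear on it.

Measured compounds:
Compound 1, `CCC(CC)O[C@@H]1C=C([S+]([O-])O)C[C@H](N)[C@H]1NC(C)=O`, in an ADME assay on MDCK cells (Canis lupus familiaris) for cytotoxicity, with a stated time of 48 h (a lower number here means that less compound is tolerated, a higher number that more compound is tolerated), gives > 100000 nM, which is a limit of the assay and not a number.
Compound 2, `CCC(CC)O[C@@H]1C=C([S+]([O-])O)C[C@H](NC(=N)N)[C@H]1NC(C)=O`, gives > 100000 nM, again a limit of the assay rather than a number.
Compound 3, `CCCCOS(=O)(=O)C1=C[C@@H](OC(CC)CC)[C@H](NC(C)=O)[C@@H](N)C1`, in this assay gives "not determined" (no result reported), so no result is reported for it.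

Compound 1 and compound 2 share a core and differ by a group of 3 heavy atoms (1 carbon, 2 nitrogen; no ring) in place of a hydrogen atom, on an amine nitrogen. The step that the two limits leave unreadable from compound 1 to compound 2 cannot be sized, since both values are limits. Compound 3 differs from compound 1 by a group of 8 heavy atoms (4 carbon, 3 oxygen, 1 sulfur; no ring) in place of a group of 3 heavy atoms (2 oxygen, 1 sulfur; no ring), on a double-bonded ring carbon, so the two cores are not the same. Compound 4, `CCCCOS(=O)(=O)C1=C[C@@H](OC(CC)CC)[C@H](NC(C)=O)[C@@H](NC(=N)N)C1`, is not yet measured; it stands to compound 3 as compound 2 stands to compound 1, by a group of 3 heavy atoms (1 carbon, 2 nitrogen; no ring) in place of a hydrogen atom, on an amine nitrogen, with the two place descriptions reading the same word for word, so this is the same kind of change on a different core. No size can be expected for the step from compound 3 to compound 4 in this assay, because the limit of > 100000 nM in this assay, at which 2 of the 3 values shown sit, leaves the earlier step unreadable. On that ground, compound 4 is expected to give about 150000 nM, likely again as a limit.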

Compound 4, half-maximal cytotoxic concentration: > 100000 nM
Compound 4 was reported as a limit; the forecaster's own chance of this, stated with the estimate: 80%; the middle value lies beyond the limit too.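

In this assay compound 4 gives > 100000 nM, which is a limit of the assay and not a number. No new step can be read from compound 2 to compound 4 or from compound 3, which has no reported result, because the values stop at the same point: the limit of > 100000 nM in this assay, at which 3 of the 4 values shown sit.

The compounds shown leave open whether either structural change alters how much compound is tolerated.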